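Replacing 4-bromophenyl with 3,5-dichlorophenyl in a cytotoxic series

This account rests on a few compounds, and the source may have more. Where it says the series, first, only, none or still open, it means among the compounds named here.

Of the compounds shown here, three sharing one core have been measured in a functional assay on Caco-2 cells (Homo sapiens) for cytotoxicity, read by cell counting, with a stated time of 48 h; on this read-out higher numbers stand for weaker inhibition and lower numbers for stronger inhibition. Compound 1 (`COc1ccccc1-n1cc(COc2cccc3cnc(Nc4cccc(Cl)c4)nc23)nn1`) reports only a limit, > 25000 nM. Compound 2 (`Clc1cccc(Nc2ncc3cccc(OCc4cn(Cc5c(Cl)cccc5Cl)nn4)c3n2)c1`) gives 9000 nM, and compound 3 (`Clc1cccc(Nc2ncc3cccc(OCc4cn(-c5ccc(Br)cc5)nn4)c3n2)c1`) gives 11000 nM. These two numbers lie within the scatter of each other, as a 1.2-fold higher number from compound 2 to compound 3 (0.09 log units; within the scatter) shows, so compound 3 holds no separate place from compound 2.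

The next compound, compound 4 (`Clc1cccc(Nc2ncc3cccc(OCc4cn(-c5cc(Cl)cc(Cl)c5)nn4)c3n2)c1`), carries 3,5-dichlorophenyl in place of 4-bromophenyl on an aromatic nitrogen of a five-membered aromatic ring with 3 nitrogen: 3,5-dichlorophenyl in place of 4-bromophenyl on an aromatic nitrogen.

The closest guide is the exchange of one chlorine- or bromine-bearing group for another at this nitrogen, a 1.2-fold higher number from compound 2 to compound 3 (0.09 log units; within the scatter), which stayed within the scatter. Two larger steps, an at least 2.7-fold lower number from compound 1 to compound 2 (0.44 log units; beyond the scatter) and an at least 2.2-fold lower number from compound 1 to compound 3 (0.35 log units; beyond the scatter), both start from a limit and both remove 2-methoxyphenyl, a group that is not involved in the present change. They therefore say little about it. Within the data shown here, no measured compound yet carries 3,5-dichlorophenyl, so the expectation rests on one small step. The expected change is a 1.1-fold lower number from compound 3 to compound 4 (0.04 log units; within the scatter), which would be no step beyond the scatter. For compound 4 the estimated value is 10000 nM, with an expected range from 5000 nM to 22000 nM.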

Compound 4, half-maximal inhibitory concentration: 8000 nM
Compound 4: the middle estimate sits 1.3-fold (0.10 log units) above what was measured, within the range that was stated.
By their numbers in this assay, from the lowest: compounds 4, 2 and 3 (each within the scatter of the next). At a limit, above all of these: compound 1.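

In this assay, the change at this aromatic nitrogen gives a 1.4-fold lower number from compound 3 to compound 4 (0.14 log units; within the scatter), and the comparison with the benzyl-linked group gives a 1.1-fold lower number from compound 2 to compound 4 (0.05 log units; within the scatter). Compounds 2, 3 and 4 therefore hold no separate places: among these compounds, 4-bromophenyl, 2,6-dichlorobenzyl and 3,5-dichlorophenyl cannot be told apart on this read-out, even though the halogens differ in kind, number and placement on the ring. Among these compounds, the step against the only group here without a halogen, an at least 3.1-fold lower number from compound 1 to compound 4 (0.49 log units; beyond the scatter), is a third case beyond the scatter, but it can be read only in one direction and gives no size, since compound 1 reports a limit: the limit of > 25000 nM in this assay, at which 1 of the 4 values shown sits.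

What the compounds leave open is whether the halogens matter at all, since a plain phenyl or a benzyl without chlorine does not appear among them, and neither does a group bearing an amine or a carboxylic acid at this nitrogen. On these data alone, the 3-chlorophenyl group on the amino nitrogen of the shared core is also the same throughout, so the effect of any other group there remains unknown.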